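Chloro in place of isopropyl on the aryl of compound 3

This account rests on a few compounds, and the source may have more. Where it says the series, first, only, none or still open, it means among the compounds named here.

Three hydroxamic acids have been measured in an assay on Sf9 cells for inhibition of protein deacetylase HDAC6 (Homo sapiens), read by fluorescence, with a stated time of 40 min, tested at 100 nM; a higher number here means more inhibition at the concentration tested (going by the name of the read-out), a lower number less inhibition. Compound 1 `O=C(NO)c1ccc(NCc2nc(-c3cccs3)nn2-c2ccc(O)cc2)cc1` gives 79.6%. Compound 2 `O=C(NO)c1ccc(NCc2nc(-c3ccc(Br)cc3)nn2-c2ccccc2)cc1` gives 54.7%. Compound 3 `CC(C)c1ccc(-n2nc(-c3ccccc3)nc2CNc2ccc(C(=O)NO)cc2)cc1` gives 52.6% in this assay. The number for compound 3 is the lowest of the three, but its gap to compound 2 lies within the scatter, so the two cannot be told apart; only compound 1 stands clearly higher, beyond the scatter.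

Compound 4 `O=C(NO)c1ccc(NCc2nc(-c3ccccc3)nn2-c2ccc(Cl)cc2)cc1` differs from compound 3 in one place: chloro in place of isopropyl on an aromatic carbon. The group that leaves is isopropyl, the group that enters is chloro, and the place is an aromatic carbon of a six-membered aromatic ring of carbon only, para to a large group. Going by the values given here, no step between the measured compounds isolates this kind of change, so there is no measured basis for a large shift. Compound 4 is expected to land near compound 3, with a step of a number 2.4 percentage points higher from compound 3 to compound 4 (within the scatter) that stays within the scatter. The estimate for compound 4 in this assay is 55%, with a range from 40% to 70%.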

Compound 4, a percentage reported as inhibition, at one concentration (the size of the read-out at that concentration, not a potency): 55.4%
For compound 4 the middle estimate is 0.4 percentage points below the measured one; the range from low to high includes it.
By their numbers in this assay, from the lowest: compounds 3, 2 and 4 (each within the scatter of the next); then compound 1.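

In this assay, the first step read at this position, a number 2.8 percentage points higher from compound 3 to compound 4 (within the scatter), comes from chloro in place of isopropyl on the aromatic carbon para to a large group. The swap from 4-isopropylphenyl to 4-chlorophenyl replaces three carbons with one chlorine, yet the two compounds cannot be told apart at the single concentration tested, so the number in this assay is level between them. Nothing measured here speaks to why the two groups read alike.

Going by these compounds, whether an amine, a carboxylic acid or a longer alkyl chain at this place would move the number remains open. On these data alone, it is also open whether chloro in place of isopropyl gives a similar step when other groups sit elsewhere on the shared core.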